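A few compounds are considered here, and "the series" means these few. Any claim that something is new, unique, unknown or untested is made for them only; others in the source may bear on it.

Measured in an ADME assay on cells (Hepatocyte, Rattus norvegicus) for metabolic stability; on this read-out lower numbers stand for a shorter-lived compound and higher numbers for a longer-lived compound:
- compound 1 `N#Cc1ccc(N2CCC(C(=O)N3N=CC[C@H]3c3cc(F)cc(F)c3)CC2)nn1`: 2.08 h
- compound 2 `O=C(C1CCN(c2ccncn2)CC1)N1N=CC[C@H]1c1ccccc1`: < 0.4 h
- compound 3 `N#Cc1cnc(N2CCC(C(=O)N3N=CC[C@H]3c3cc(F)cc(F)c3)CC2)cn1`: 1.78 h

Compound 2 stands at the limit of < 0.4 h in this assay, at which 1 of the 3 values shown sits, which is a limit and not a number. Compound 4 `CC(=O)N1CCC(C(=O)N2N=CC[C@H]2c2ccccc2)CC1` has acetyl in place of pyrimidin-4-yl on an amine nitrogen in a ring. Among the compounds with values here, the only measured step, a 1.2-fold lower number from compound 1 to compound 3 (0.07 log units; within the scatter), swaps one six-membered aromatic ring with 2 hetero atoms for another on an amine nitrogen in a ring. Within the data shown here, no measured step replaces such a ring with acetyl, so this is a weak guide. It gives no firm reason to expect a large move in this assay. The expected result is an at least 1.2-fold higher number from compound 2 to compound 4 (0.09 log units; that floor lies within the scatter), a small step upward at most and none clearly beyond the scatter. For compound 4 the estimated half-life is 0.5 h, with an expected range of 0.25 h to 1.2 h.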

Compound 4, half-life: > 3.11 h
Compound 4 ended at the assay's limit; the forecaster's own chance of this, stated with the estimate: 40%; at least 6.2-fold (0.79 log units) between middle value and limit.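

In this assay, acetyl in place of pyrimidin-4-yl on an amine nitrogen in a ring gives an at least 7.7-fold higher number from compound 2 to compound 4 (0.89 log units; beyond the scatter). The earlier swap of one aromatic ring for another at this place stayed within the scatter, so this is the first sign among these compounds that the group here can clearly shift the half-life. As far as these compounds go, the step runs between two limits of the assay, not two numbers, so its true size stays unknown.

The compounds shown do not tell whether the shift comes from acetyl itself or from losing the aromatic ring. A propanoyl group or a methyl carbamate in the same place would help to separate the two.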